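The source may hold more compounds than are shown below. What is called first, only, known or untested is meant among the compounds shown, and "the series" means these compounds.

Compound 1 `COc1cc(-c2ncnn2-c2cccc(N)c2)cc(OC)c1OC` is one of three compounds built on the same core and tested in a functional assay on Jurkat cells (Homo sapiens) for antiproliferative activity, read by MTT assay, with a stated time of 72 h; a lower number here means a stronger inhibitor, a higher number a weaker inhibitor. In that assay compound 1 gives > 10000 nM, which is a limit of the assay rather than a number. Compound 2 `COc1cc(-c2ncnn2-c2ccc(Cl)c(Cl)c2)cc(OC)c1OC` gives > 10000 nM, again only a limit. Compound 3 `COc1cc(-c2ncnn2-c2ccc(F)cc2)cc(OC)c1OC` gives > 10000 nM, also a limit. The steps among them, a step that the two limits leave unreadable from compound 1 to compound 2, a step that the two limits leave unreadable from compound 1 to compound 3 and a step that the two limits leave unreadable from compound 2 to compound 3, thus show neither size nor direction, and the limit of > 10000 nM in this assay, at which 3 of the 3 values shown sit, is all the numbers offer. Compound 4 `COc1cc(-c2ncnn2-c2cccc([N+](=O)[O-])c2)cc(OC)c1OC` differs from compound 1 by nitro in place of amino on an aromatic carbon. Within the data shown here, no measured step touches this exchange, so the expectation for compound 4 rests only on where compound 1 sits. For compound 4 the expected step is a step that the limit leaves unreadable from compound 1 to compound 4, leaving it at or near the limit. Compound 4 is estimated at 15000 nM, between 4000 nM and 60000 nM.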

Compound 4, half-maximal inhibitory concentration: > 10000 nM
Compound 4: no number, only a limit (the forecaster's own chance of this, stated with the estimate: 80%); the middle value lies beyond the limit too.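

Like compound 1, compound 4 gives only a limit in this assay, so no step can be read between them: the limit of > 10000 nM in this assay, at which 4 of the 4 values shown sit. The compounds shown leave open which group, if any, would give a readable number on the shared core.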